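A halogen swap among compounds held at a limit

The source may hold more compounds than are shown below. What is called first, only, known or untested is meant among the compounds shown, and "the series" means these compounds.

Compound 1 (`OC[C@H]1O[C@@H](n2cnc3c(NCc4cccc(F)c4)ncnc32)[C@H](O)[C@@H]1O`), compound 2 (`COc1cc(CNc2ncnc3c2ncn3[C@@H]2O[C@H](CO)[C@@H](O)[C@H]2O)cc(OC)c1`), compound 3 (`OC[C@H]1O[C@@H](n2cnc3c(NCc4c(F)ccc(F)c4F)ncnc32)[C@H](O)[C@@H]1O`) and compound 4 (`OC[C@H]1O[C@@H](n2cnc3c(NCc4ccc(F)c(Cl)c4)ncnc32)[C@H](O)[C@@H]1O`) share one core and differ in the aryl group on a saturated chain carbon bound to a nitrogen on an aromatic ring. In a functional assay on G-361 cells (Homo sapiens) for antiproliferative activity, with a stated time of 72 h (on this read-out lower numbers stand for stronger inhibition and higher numbers for weaker inhibition), compound 1 gives > 166000 nM, which is a limit and not a number. For compound 2 the entry in this assay reads "not determined" (no result reported). Compound 3 stands at > 166000 nM, again a limit and not a number, so it has no exact position on the scale.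

The change now in question is 3-chloro-4-fluorophenyl in place of 2,3,6-trifluorophenyl on a saturated chain carbon bound to a nitrogen on an aromatic ring, which puts 3-chloro-4-fluorophenyl in place of 2,3,6-trifluorophenyl. Within the data shown here, the only measured step at this place is a step that the two limits leave unreadable from compound 1 to compound 3, so it offers no size to carry over. The remaining guide is the limit of > 166000 nM in this assay, at which 2 of the 3 values shown sit. Resting on compound 3 and its limit of > 166000 nM, no step beyond the scatter is expected in this assay, and another limit is the likeliest report. The expected step is a number no higher from compound 3 to compound 4 (the limit leaves the size open). The estimate for compound 4 is 166000 nM, with an expected range from 50000 nM to 250000 nM.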

Compound 4, half-maximal inhibitory concentration: > 166000 nM
Compound 4 ended at the assay's limit; the forecaster's own chance of this, stated with the estimate: 75%; the middle value sits exactly at the limit.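

In this assay, compound 4 joins compound 1 and compound 3 at a limit and not a number, so no step among these three compounds can be read: the limit of > 166000 nM in this assay, at which 3 of the 4 values shown sit.

The compounds shown leave open how far these aryl groups differ in strength, and whether any aryl group on the shared core gives a measurable value.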